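A few compounds are considered here, and "the series" means these few. Any claim that something is new, unique, unknown or untested is made for them only; others in the source may bear on it.

Compound 1 `c1ccc(CCc2ccc3c(NCCCNCc4ccco4)ccnc3c2)cc1` gives 23 10^-6 cm/s in an ADME assay for permeability, using PAMPA, with a stated time of 30 min, at pH 7.4; a lower number here means that the compound crosses the layer more slowly, a higher number that the compound crosses the layer faster. Compound 2 `CCC(CC)c1ccc2c(NCCCNCc3ccco3)ccnc2c1` gives 23 10^-6 cm/s and compound 3 `COc1ccc(-c2ccc3c(NCCCNCc4ccco4)ccnc3c2)cc1` gives 237 10^-6 cm/s, so compound 1 stands level with compound 2, the two together the lowest of the three numbers, and compound 3 lies furthest from it. The measured steps, no change at the digits printed from compound 1 to compound 2 (within the scatter) and a 10-fold higher number from compound 1 to compound 3 (1.01 log units; beyond the scatter), both alter the group on an aromatic carbon of the shared core. Among the compounds with values here, compound 4 `COc1cccc(CNCCCNc2ccnc3cc(CCc4ccccc4)ccc23)c1O` differs from compound 1 at another place: 2-hydroxy-3-methoxyphenyl in place of furan-2-yl on a saturated chain carbon bound to an amine nitrogen No measured step touches that position, so nothing in the data directly bears on this change. Compound 4 is therefore expected to remain close to its parent, with a 1.5-fold lower number from compound 1 to compound 4 (0.19 log units; within the scatter) small. The estimated value of compound 4 in this assay is 15 10^-6 cm/s, with a range from 5 10^-6 cm/s to 45 10^-6 cm/s.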

Compound 4, apparent permeability: 23 10^-6 cm/s
Compound 4: middle estimate off by 1.5-fold (0.19 log units), on the low side; the measured number falls inside the stated range.
By their numbers in this assay, from the lowest: compounds 1, 2 and 4 (each within the scatter of the next); then compound 3.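

In this assay, within the data shown here, the move from furan-2-yl to 2-hydroxy-3-methoxyphenyl gives no change at the digits printed from compound 1 to compound 4 (within the scatter) and is the first reading at this position. It shows that, with phenethyl on the core, this place accepts a group of 9 heavy atoms in place of one of 5, carrying a hydrogen-bond donor that furan-2-yl lacks, without a shift beyond the scatter. No measured evidence explains this result. Still open, going by these compounds, is whether the same exchange would leave compound 3 unchanged, and how a carboxylic acid or a morpholine at this place would read.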